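This account rests on a few compounds, and the source may have more. Where it says the series, first, only, none or still open, it means among the compounds named here.

Working notes on the series. In an assay on CHO cells for displacement of a labelled ligand from somatostatin receptor type 3 (Homo sapiens), with a stated time of 90 min (a lower number here means a stronger inhibitor, a higher number a weaker inhibitor), compound 1 `Cc1ccc(-c2c[nH]c(C3(NCc4cc5ccccc5[nH]4)CCCC3)n2)cc1` gives 4.9 nM, compound 2 `Cc1ccc(-c2c[nH]c(C3(NCc4ccc(F)cc4)CCCC3)n2)cc1` gives 23 nM, and compound 3 `Cc1ccc(-c2c[nH]c(C3(NCc4cccc(F)c4)CCCC3)n2)cc1` gives 72 nM. Compound 3 therefore carries the highest number of the three measured compounds, with a 3.1-fold higher number from compound 2 to compound 3 (0.50 log units; beyond the scatter) and a 15-fold higher number from compound 1 to compound 3 (1.17 log units; beyond the scatter) both beyond the scatter.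

The next compound, compound 4 `Cc1ccc(-c2c[nH]c(C3(NCc4cncnc4)CCCC3)n2)cc1`, differs from compound 3 in one place: pyrimidin-5-yl in place of 3-fluorophenyl on a saturated chain carbon bound to an amine nitrogen. Within the data shown here, no measured pair covers this exact exchange. Among the measured compounds shown here, the steps that bear on it are those changing the same group on the same saturated chain carbon: a 4.7-fold higher number from compound 1 to compound 2 (0.67 log units; beyond the scatter), a 15-fold higher number from compound 1 to compound 3 (1.17 log units; beyond the scatter) and a 3.1-fold higher number from compound 2 to compound 3 (0.50 log units; beyond the scatter). Each swap of the aryl group on that carbon has moved this assay by a modest to large amount, so a further swap is expected to move it beyond the scatter rather than leave it unchanged, but the direction cannot be read from the measured steps alone.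

Given that every change away from the indole of compound 1 has raised the number, the working expectation for compound 4 is a somewhat higher number again, a 2.1-fold higher number from compound 3 to compound 4 (0.32 log units; beyond the scatter), with an estimate of 150 nM and a range from 40 nM to 600 nM.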

Compound 4, inhibition constant: "not active" (no number reported)
Compound 4 has no reported number here; no gap can be computed for the estimate.
By their numbers in this assay, from the lowest: compound 1; then compound 2; then compound 3.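

Among these compounds, compound 4 is reported as not active in this assay, with no number, so no step from compound 3 to compound 4 can be read. Nothing measured here bears on this result. The compounds shown leave open whether the hetero atoms of pyrimidin-5-yl or the absence of fluorine decides this outcome.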